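This account rests on a few compounds, and the source may have more. Where it says the series, first, only, none or still open, it means among the compounds named here.

Working notes on the series. In a functional assay on HL-60 cells (Homo sapiens) for cytotoxicity, read by CCK-8 assay, with a stated time of 24 h (a higher number here means a weaker inhibitor, a lower number a stronger inhibitor), compound 1 `C=CC(=O)N1C(=O)CC(c2ccc(Br)cc2)Sc2ccccc21` gives 126000 nM. Compound 2 `C=CC(=O)N1C(=O)CC(c2ccc([N+](=O)[O-])cc2)Sc2ccccc21` gives 107000 nM, and compound 3 `C=CC(=O)N1C(=O)CC(c2ccc(C(=O)OC)cc2)Sc2ccccc21` gives 102000 nM. Compound 3 therefore stands level with the other two, as all three values lie within the scatter of one another.

The next structure is compound 4 `C=CC(=O)N1C(=O)CC(c2ccc(C#N)cc2)Sc2ccccc21`, which has cyano in place of methoxycarbonyl on an aromatic carbon, para to a large group: cyano in place of methoxycarbonyl on an aromatic carbon. The shared core stays unchanged.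

Going by the values given here, three measured steps bear on this change, all exchanges at the same place: a 1.2-fold lower number from compound 1 to compound 2 (0.07 log units; within the scatter), a 1.2-fold lower number from compound 1 to compound 3 (0.09 log units; within the scatter) and a 1.0-fold lower number from compound 2 to compound 3 (0.02 log units; within the scatter). Each lies within the scatter. None of them involves cyano, so the support is indirect and rests on only three substituents: bromo, nitro and methoxycarbonyl. With no exchange so far resolved from the scatter, no step beyond the scatter is expected in this assay, and no direction can be assigned. The expected change is a 1.0-fold higher number from compound 3 to compound 4 (0.01 log units; within the scatter), which is no real shift. For compound 4 the estimated value is 105000 nM, with an expected range of 65000 nM to 165000 nM.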

Compound 4, half-maximal inhibitory concentration: 115000 nM
Compound 4: the middle estimate sits 1.1-fold (0.04 log units) below what was measured, within the range that was stated.
By their numbers in this assay, from the lowest: compounds 3, 2, 4 and 1 (each within the scatter of the next).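

In this assay, cyano joins the exchanges at this position without a resolved shift: the steps are a 1.1-fold higher number from compound 3 to compound 4 (0.05 log units; within the scatter) and a 1.1-fold higher number from compound 2 to compound 4 (0.03 log units; within the scatter) and a 1.1-fold lower number from compound 1 to compound 4 (0.04 log units; within the scatter). Going by these compounds alone, this extends the flat picture to a fourth substituent, and compounds 1 to 4 now show no exchange at this aromatic carbon that lies beyond the scatter, with no compound among them going against this. The change from methoxycarbonyl, with 4 heavy atoms and 2 hydrogen-bond acceptors, to cyano, with 2 heavy atoms and 1 hydrogen-bond acceptor, also leaves the number within the scatter, and no measurement at hand offers an explanation for the absence of a shift.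

The compounds shown leave open whether an amine, a carboxylic acid or a longer chain at this position would produce a step beyond the scatter. They also leave open whether a change elsewhere on the shared core would move the number, since all four compounds differ only at this one place.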